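A few compounds are considered here, and "the series" means these few. Any claim that something is new, unique, unknown or untested is made for them only; others in the source may bear on it.

Measured compounds:
- compound 1 `CC/N=C(/NC#N)NCCCCn1nc(-c2ccccc2)ccc1=O`: in a functional assay on the whole organism (stomach) with Rattus norvegicus as the target (a lower number here means that less compound is needed, a higher number that more compound is needed for the effect), compound 1 gives 92 mg/kg.
- compound 2 `C/N=C(/NC#N)NCCCCn1nc(-c2ccc(C)cc2)ccc1=O`: in this assay compound 2 gives only a limit, > 100 mg/kg.
- compound 3 `O=c1ccc(-c2ccccc2)nn1CCCC/N=C(\S)Nc1ccc(F)cc1`: in this assay compound 3 likewise gives only a limit, > 100 mg/kg.

Compound 2 thus stands at the limit of > 100 mg/kg in this assay, at which 2 of the 3 values shown sit, so no number is known for it, only that the half-maximal dose was not reached within the tested range; one further value of the three shown is also a limit, and only compound 1 carries a number.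

The step to compound 4 `C/N=C(/NC#N)NCCCCn1nc(C)ccc1=O` is methyl in place of 4-methylphenyl on an aromatic carbon. Going by the values given here, no pair of measured compounds that differ in one place is available, so the size of this step has no direct precedent; the only comparison is that compound 1, which carries the unsubstituted phenyl on the same core, reaches a number just under the limit, while compound 2 does not.

Shrinking the aryl to a single methyl is expected to leave compound 4 no stronger than its parent, with a fair chance that this assay again reports only a limit. For compound 4 the estimate is 160 mg/kg, within 60 mg/kg to 450 mg/kg. The implied step from compound 2 to compound 4 is expected to be a step that the limit leaves unreadable from compound 2 to compound 4, not clearly beyond the scatter.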

Compound 4, dose for half-maximal effect: > 100 mg/kg
Compound 4: no number, only a limit; the forecaster's own chance of this, stated with the estimate: 65%; the middle value does not contradict the limit.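

Compound 2 and compound 4 both give only a limit, so the step between them, methyl in place of 4-methylphenyl on an aromatic carbon, cannot be read: the limit of > 100 mg/kg in this assay, at which 3 of the 4 values shown sit.

The compounds shown leave open whether this exchange changes the dose needed for the half-maximal effect at all, and in which direction.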